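Adding ethoxy to the methyl of compound 3

A few compounds are considered here, and "the series" means these few. Any claim that something is new, unique, unknown or untested is made for them only; others in the source may bear on it.

compound 1 `CC1(C)Oc2ccc(C#N)cc2[C@@H](N2CCCC2=O)[C@]1(C)O`: 4000 nM
compound 2 `CC1(C)Oc2ccc(C#N)cc2[C@@H](On2ccccc2=O)[C@]1(C)O`: > 100000 nM
compound 3 `CC1(C)Oc2ccc(C#N)cc2[C@@H](Oc2ccc(=O)[nH]n2)[C@]1(C)O`: 6 nM

In a functional assay for inhibition, with Sus scrofa as the target (a higher number here means a weaker inhibitor, a lower number a stronger inhibitor), compound 3 gives the lowest number, 6 nM, which makes it the strongest inhibitor of the three. The value for compound 2, > 100000 nM, is a limit of the assay and not a number. Even so, the gaps are clear: a 670-fold lower number from compound 1 to compound 3 (2.82 log units; beyond the scatter) and an at least 16000-fold lower number from compound 2 to compound 3 (4.22 log units; beyond the scatter).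

Compound 4 `CCOC[C@]1(O)[C@H](Oc2ccc(=O)[nH]n2)c2cc(C#N)ccc2OC1(C)C` keeps everything in compound 3 except one place: ethoxy in place of hydrogen on a saturated chain carbon bound to a saturated ring carbon. Put another way, a methyl becomes an ethoxymethyl. Going by the values given here, no measured step changes this methyl, since all three steps exchange a different group. They therefore give no direct guide to this change and show only how far numbers can move in this assay, as in an at least 25-fold higher number from compound 1 to compound 2 (1.39 log units; beyond the scatter). Compound 3 already has the lowest number at 6 nM, so a rise seems more likely than a further fall, though this is a judgement and not a measured trend.

A moderate loss is expected, namely a 5.0-fold higher number from compound 3 to compound 4 (0.70 log units; beyond the scatter) in this assay, with wide uncertainty. For compound 4 the estimated value is 30 nM, with an expected range from 4 nM to 250 nM.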

Compound 4, half-maximal inhibitory concentration: 50000 nM
Compound 4: middle estimate off by 1700-fold (3.22 log units), on the low side; measured number above the stated range.
By their numbers in this assay, from the lowest: compound 3; then compound 1; then compound 4. At a limit, above all of these: compound 2.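

In this assay, the methyl of compound 3 turns out to be a highly sensitive place, with an 8300-fold higher number from compound 3 to compound 4 (3.92 log units; beyond the scatter). The earlier steps shown here all exchanged a different group, so they showed that this other group matters but said nothing about the methyl; this step shows that changing methyl to ethoxymethyl is enough on its own to lose almost all of the strength of compound 3, even with the group that gives that strength left in place. The result for compound 4 remains a real number, and among the compounds shown only compound 2 has a value that is a limit of the assay rather than a number: the limit of > 100000 nM in this assay, at which 1 of the 4 values shown sits.

With only one change at this place, the compounds shown cannot separate the added chain length from the added oxygen, and an ethyl, a propyl, a hydroxymethyl or an aminomethyl in place of the methyl would help to tell these apart. Going by these compounds alone, they also leave open whether the ethoxymethyl would cost as much with a different group in place of the one carried by compound 3 and compound 4, such as the five-membered ring of compound 1.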